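Trifluoromethyl for methyl in two matched pairs

This account rests on a few compounds, and the source may have more. Where it says the series, first, only, none or still open, it means among the compounds named here.

Measured in a functional assay on PC-3 cells (Homo sapiens) for cytotoxicity, read by MTT assay, with a stated time of 72 h; a lower number here means a stronger inhibitor, a higher number a weaker inhibitor:
compound 1 `Cc1c(C(=O)Nc2ccc(Oc3ccnc4[nH]ccc34)c(F)c2)nnn1-c1ccc(F)c(F)c1` gives 6540 nM
compound 2 `Cc1c(C(=O)Nc2ccc(Oc3ccnc4[nH]ccc34)cc2)nnn1-c1ccccc1F` gives 3450 nM
compound 3 `O=C(Nc1ccc(Oc2ccnc3[nH]ccc23)c(F)c1)c1nnn(-c2ccc(F)c(F)c2)c1C(F)(F)F` gives 2480 nM

Among the compounds with values here, the one matched pair is compound 1 to compound 3: trifluoromethyl in place of methyl on an aromatic carbon, which gave a 2.6-fold lower number from compound 1 to compound 3 (0.42 log units; beyond the scatter). The values of compound 2 and compound 3 lie within the scatter of each other, as do those of compound 2 and compound 1. How the core of compound 2 differs from that of compound 1 is not broken down here.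

Compound 4 `O=C(Nc1ccc(Oc2ccnc3[nH]ccc23)cc1)c1nnn(-c2ccccc2F)c1C(F)(F)F` is not yet measured. It differs from compound 2 by trifluoromethyl in place of methyl on an aromatic carbon. The place is not identical: in compound 1 the ring atom bears a 3,4-difluorophenyl group (8 heavy atoms), in compound 2 a 2-fluorophenyl group (7 heavy atoms), so this is the same kind of change, not the same. Within the data shown here, a step of similar size is expected, a 2.5-fold lower number from compound 2 to compound 4 (0.39 log units; beyond the scatter), because the only matched pair shows a 2.6-fold lower number from compound 1 to compound 3 (0.42 log units; beyond the scatter). Compound 4 is estimated at 1400 nM, expected between 600 nM and 3500 nM.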

Compound 4, half-maximal inhibitory concentration: 3690 nM
For compound 4 the middle estimate is 2.6-fold (0.42 log units) below the measured one; the whole stated range lies below it.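

In this assay, the step on the core of compound 2 is a 1.1-fold higher number from compound 2 to compound 4 (0.03 log units; within the scatter). Trifluoromethyl in place of methyl therefore does not carry a fixed step from one core to the other in this series: the same change on two cores in this assay, a 2.6-fold lower number (0.42 log units; beyond the scatter) from compound 1 to compound 3 and a 1.1-fold higher number (0.03 log units; within the scatter) from compound 2 to compound 4, 2.8-fold (0.45 log units) apart, beyond the scatter of two such steps. Two pairs do not show which difference between the cores sets the size of the step, nor whether either step would hold on a third core; the 3,4-difluorophenyl group against the 2-fluorophenyl group is only one such difference.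

Open, as far as these compounds go, is how an ethyl group, a nitrile or an amine on the same ring carbon would read on these two cores. Also open, from the compounds shown here alone, is whether the size of the step follows the group on the ring nitrogen or another part of the core.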